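This account rests on a few compounds, and the source may have more. Where it says the series, first, only, none or still open, it means among the compounds named here.

The measured compounds:
Compound 1, `COc1ccc(/C=C/c2cc(OC)cc(OC)c2/C=C/C(=O)c2ccccc2)cc1`, in a functional assay on A549 cells (Homo sapiens) for antiproliferative activity, read by MTT assay, with a stated time of 48 h (on this read-out higher numbers stand for weaker inhibition and lower numbers for stronger inhibition), gives 3.9 ug/mL.
Compound 2, `CCCCCCOc1ccc(C(=O)/C=C/c2c(/C=C/c3ccc(OC)cc3)cc(OC)cc2OC)cc1`, in this assay gives 8.4 ug/mL.
Compound 3, `COc1ccc(/C=C/c2cc(OC)cc(OC)c2/C=C/C(=O)c2ccc(Cl)c(Cl)c2)cc1`, in this assay gives 5.9 ug/mL.

Compound 3 holds the second highest of these three numbers. Its nearest neighbour is compound 2, whose number sits within the scatter of that of compound 3; compound 1 is the furthest away, and that gap too is within the scatter, as the step of a 1.5-fold higher number from compound 1 to compound 3 (0.18 log units; within the scatter) shows.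

Compound 4, `COc1ccc(/C=C/c2cc(OC)cc(OC)c2/C=C/C(=O)c2ccc(F)cc2)cc1`, differs from compound 3 only at the carbonyl carbon: 4-fluorophenyl in place of 3,4-dichlorophenyl on a carbonyl carbon. Going by the values given here, the one measured step that bears on this place is a 1.5-fold higher number from compound 1 to compound 3 (0.18 log units; within the scatter), which stayed within the scatter when phenyl became 3,4-dichlorophenyl. The other step, a 2.2-fold higher number from compound 1 to compound 2 (0.33 log units; beyond the scatter), concerns a different part of the molecule and says little here. Among the compounds with values here, with the only relevant precedent showing no change beyond the scatter, the writer expects compound 4 to move by a 1.2-fold lower number from compound 3 to compound 4 (0.07 log units; within the scatter), that is, no step beyond the scatter. The estimate for compound 4 is therefore 5 ug/mL, with a range from 2.5 ug/mL to 10 ug/mL.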

Compound 4, half-maximal inhibitory concentration: 6.6 ug/mL
Estimate against measurement, compound 4: 1.3-fold (0.12 log units) below, and the stated range covers the measured number.
By their numbers in this assay, from the lowest: compounds 1, 3, 4 and 2 (each within the scatter of the next, the first and the last beyond it).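

In this assay, the group on the carbonyl carbon has now been changed a second time, and the number again holds: 4-fluorophenyl in place of 3,4-dichlorophenyl gives a 1.1-fold higher number from compound 3 to compound 4 (0.05 log units; within the scatter) and fluoro in place of hydrogen gives a 1.7-fold higher number from compound 1 to compound 4 (0.23 log units; within the scatter) without leaving the scatter. Hexyloxy, whose step from hydrogen alone passed the scatter, is not separated from fluoro, with a 1.3-fold lower number from compound 2 to compound 4 (0.10 log units; within the scatter) also lying within it, so the halogen and hexyloxy variants cannot be told apart here. No measurement shown explains this flat response.

On these data alone, whether an amine, a carboxylic acid or a chain longer than hexyloxy on that phenyl would move the number beyond the scatter stays open. So does the effect of any change to the rest of the shared core.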